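The compounds below may be only part of what the source reports. "The series", "measured", "known", "first", "only" and "open" are said of these compounds alone.

Measured in a functional assay on MCF7 cells (Homo sapiens) for inhibition, read by MTT assay, with a stated time of 72 h; on this read-out lower numbers stand for stronger inhibition and higher numbers for weaker inhibition:

Compound 1 `Cc1cc(Nc2cc(-c3ccccc3)[nH]n2)n2nc(SCc3csc4ccccc34)nc2n1`: 3470 nM
Compound 2 `Cc1cc(Nc2cc(-c3ccccc3)[nH]n2)n2nc(SCc3cccc(Br)c3)nc2n1`: 5140 nM
Compound 3 `Cc1cc(Nc2cc(-c3ccccc3)[nH]n2)n2nc(SCCc3ccccc3)nc2n1`: 2700 nM

Compound 3 shows the lowest of the three numbers, yet its steps from the others, a 1.3-fold lower number from compound 1 to compound 3 (0.11 log units; within the scatter) and a 1.9-fold lower number from compound 2 to compound 3 (0.28 log units; within the scatter), both lie within the scatter, so no real order can be read among them.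

Compound 4 `Cc1cc(Nc2cc(-c3ccccc3)[nH]n2)n2nc(SCC3CC3)nc2n1` carries one change: cyclopropyl in place of benzyl on a saturated chain carbon bound to a sulfur. All three measured steps, including a 1.5-fold higher number from compound 1 to compound 2 (0.17 log units; within the scatter), swapped one group for another on a saturated chain carbon bound to a sulfur and stayed within the scatter. None of them removed an aromatic ring, so this step is less well anchored. The step is expected to be a 1.3-fold higher number from compound 3 to compound 4 (0.11 log units; within the scatter), with compound 4 estimated at 3500 nM, between 1500 nM and 9000 nM.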

Compound 4, half-maximal inhibitory concentration: > 50000 nM
Compound 4: only a limit was reported; the forecaster's own chance of this, stated with the estimate: 5%; middle value at least 14-fold (1.15 log units) from the limit.
By their numbers in this assay, from the lowest: compounds 3, 1 and 2 (each within the scatter of the next). At a limit, above all of these: compound 4.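

Compound 4 gives only a limit in this assay: the limit of > 50000 nM in this assay, at which 1 of the 4 values shown sits. The three groups that carry an aromatic ring stayed within the scatter of each other at this place, whereas cyclopropyl gives an at least 18-fold higher number from compound 3 to compound 4 (1.26 log units; beyond the scatter), an at least 9.7-fold higher number from compound 2 to compound 4 (0.98 log units; beyond the scatter) and an at least 14-fold higher number from compound 1 to compound 4 (1.15 log units; beyond the scatter). So this place accepted quite different aromatic groups, and the one change that removed the aromatic ring was also the one that lost measurable inhibition.

Going by these compounds, what remains open is whether that loss follows the aromatic ring itself or the smaller number of heavy atoms. A cyclohexyl group here would separate the two.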